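A few compounds are considered here, and "the series" means these few. Any claim that something is new, unique, unknown or untested is made for them only; others in the source may bear on it.

Measured so far in a functional assay on B16-F10 cells (Mus musculus) for antiproliferative activity, read by MTT assay, with a stated time of 48 h; on this read-out higher numbers stand for weaker inhibition and lower numbers for stronger inhibition:
- compound 1 `CC(=O)N1N=C(c2ccc3ccccc3c2)OC1c1ccc(Br)cc1` gives 4.68 ug/mL
- compound 2 `CC(=O)N1N=C(c2ccc3ccccc3c2)OC1c1cccnc1` gives 3.06 ug/mL
- compound 3 `CC(=O)N1N=C(c2ccc3ccccc3c2)OC1c1ccncc1` gives 2.97 ug/mL

All three numbers lie within the scatter of one another, so compound 3 holds no distinct rank in the set. The steps that reach it are a 1.6-fold lower number from compound 1 to compound 3 (0.20 log units; within the scatter) and a 1.0-fold lower number from compound 2 to compound 3 (0.01 log units; within the scatter), and the remaining pair shows a 1.5-fold lower number from compound 1 to compound 2 (0.18 log units; within the scatter) as well.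

Compound 4 `CC(=O)N1N=C(c2ccc3ccccc3c2)OC1c1ccsc1` keeps the shared core and carries thiophen-3-yl in place of pyridin-4-yl on a saturated ring carbon. All three measured steps are exchanges of one aromatic ring at this same carbon, and none leaves the scatter. On these data alone, no five-membered aromatic ring has been measured at this place, so the new group itself remains untested and the range is kept wide.

The expected outcome in this assay is no shift beyond the scatter, and the estimated step is a 1.1-fold higher number from compound 3 to compound 4 (0.06 log units; within the scatter). Compound 4 is expected near 3.4 ug/mL, with an estimated range from 1.8 ug/mL to 6.5 ug/mL.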

Compound 4, half-maximal inhibitory concentration: 8.56 ug/mL
The estimate for compound 4 lay 2.5-fold (0.40 log units) below the measured number; measured number above the stated range.
By their numbers in this assay, from the lowest: compounds 3, 2, 1 and 4 (each within the scatter of the next, the first and the last beyond it).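

In this assay, this carbon now shows steps beyond the scatter, a 2.9-fold higher number from compound 3 to compound 4 (0.46 log units; beyond the scatter) and a 2.8-fold higher number from compound 2 to compound 4 (0.45 log units; beyond the scatter), whereas the exchanges among the earlier aromatic rings all stayed within it. The change to thiophen-3-yl thus separates compound 4 from the pyridin-3-yl and pyridin-4-yl compounds, though only modestly, and not from the 4-bromophenyl compound (a 1.8-fold higher number from compound 1 to compound 4 (0.26 log units; within the scatter)), so the carbon tolerates this five-membered ring about as well as it does 4-bromophenyl. No measurement at hand accounts for the shift.

Still open, on these data alone, is whether the higher number follows the sulfur, the five-membered ring or the attachment point, which furan-3-yl and thiophen-2-yl at this carbon would help to separate. Also open, as far as these compounds go, is how a non-aromatic group at this carbon, such as a piperidine, would compare.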